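The source may hold more compounds than are shown below. What is called first, only, known or untested is meant among the compounds shown, and "the series" means these compounds.

Compound 1 `O=C(O)Cc1sc(C(c2ccccc2)c2ccc(F)cc2)nc1-c1ccc(Cl)cc1` gives 36 nM in an in vitro functional assay on HEK285-7 cells for antagonist activity at prostaglandin D2 receptor 2 (Homo sapiens), read by BRET and beta-arrestin recruitment; on this read-out lower numbers stand for stronger inhibition and higher numbers for weaker inhibition. Compound 2 `O=C(O)Cc1sc(C(c2ccc(F)cc2)c2ccc(F)cc2)nc1-c1ccc(Cl)cc1` gives 180 nM in this assay and so holds the higher of the two numbers shown; its nearest neighbour is compound 1, separated from it by a 5.0-fold higher number from compound 1 to compound 2 (0.70 log units; beyond the scatter). Compound 3 `O=C(O)Cc1sc(C(c2ccccc2)c2ccccc2)nc1-c1ccc(C(F)(F)F)cc1` gives only a limit of the assay, > 100000 nM, in this assay.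

Compound 4 `O=C(O)Cc1sc(C(c2ccc(F)cc2)c2ccc(F)cc2)nc1-c1cc(F)cc(F)c1` differs from compound 2 by 3,5-difluorophenyl in place of 4-chlorophenyl on an aromatic carbon. Within the data shown here, the only measured step, a 5.0-fold higher number from compound 1 to compound 2 (0.70 log units; beyond the scatter), changes the diphenylmethyl part and not the ring that is exchanged here, so it speaks to this change only loosely. Compound 3 differs from compound 1 in two places, one of them the same ring that the change to compound 4 replaces. Compound 1 gives 36 nM. Compound 3, by contrast, sits at the limit (the limit of > 100000 nM in this assay, at which 1 of the 3 values shown sits). That comparison, though it mixes two changes, is the only hint that this ring matters, and it points toward loss. Compound 4 is therefore expected to give a higher number than compound 2, by a step of an 8.3-fold higher number from compound 2 to compound 4 (0.92 log units; beyond the scatter) in this assay. The estimate for compound 4 is 1500 nM, with a range from 300 nM to 20000 nM.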

Compound 4, half-maximal inhibitory concentration: 340 nM
Compound 4: the middle estimate sits 4.4-fold (0.64 log units) above what was measured; measured number inside the range.
By their numbers in this assay, from the lowest: compound 1; then compounds 2 and 4 (each within the scatter of the next). At a limit, above all of these: compound 3.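

In this assay, the exchange of 4-chlorophenyl for 3,5-difluorophenyl at the aromatic carbon next to the ring nitrogen gives a 1.9-fold higher number from compound 2 to compound 4 (0.28 log units; within the scatter). Among these compounds, this is the first reading of this ring on its own, since compound 3 changes two places at once, and it shows that the position accepts a different substitution pattern on the phenyl ring without a step beyond the scatter, at least with the diphenylmethyl part of compound 2 in place. No measurement shown gives a reason for this result.

Compound 3 gives > 100000 nM, a limit of the assay, and with two places changed from compound 1, the compounds shown do not tell whether its ring with trifluoromethyl or its unsubstituted diphenylmethyl part accounts for that limit. Also open, from the compounds shown here alone, is whether the same exchange would hold on the diphenylmethyl part of compound 1, and how the position would respond to a methoxy group, a nitrile or an unsubstituted phenyl ring.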